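Amino Substituent on the Anilide of a Low-Activity Series

This account rests on a few compounds, and the source may have more. Where it says the series, first, only, none or still open, it means among the compounds named here.

Measured so far:
compound 1, `CNC(=O)c1c(O)c2cccnc2n(-c2ccccc2)c1=O`, 9.6%
compound 2, `O=C(Nc1ccccc1)c1c(O)c2cccnc2n(-c2ccccc2)c1=O`, 4.6%

In a functional assay on the whole organism for inhibition, with Rattus norvegicus as the target, read by paw edema, at a dose of 100 mg/kg by the oral route (on this read-out higher numbers stand for more inhibition at the one dose given (going by the name of the read-out) and lower numbers for less inhibition), compound 1 gives 9.6% and compound 2 gives 4.6%. Among the compounds with values here, the one step between them, a number 5 percentage points lower from compound 1 to compound 2 (within the scatter), shows that swapping the group on the amide nitrogen left the read-out essentially where it was. Compound 2 thus stands at a small number, close to compound 1 within the scatter, with both compounds showing little inhibition.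

Compound 3, `Nc1ccc(NC(=O)c2c(O)c3cccnc3n(-c3ccccc3)c2=O)cc1`, differs from compound 2 by amino in place of hydrogen on an aromatic carbon. Within the data shown here, no measured step bears directly on an amino group in this place; the only step available, the change of the amide substituent, was within the scatter. There is therefore no basis for expecting a step beyond the scatter in this assay in either direction.

Compound 3 is accordingly expected to give 6%, in a range from -6% to 20%, meaning an estimated step of a number 1.4 percentage points higher from compound 2 to compound 3 (within the scatter).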

Compound 3, a percentage reported as inhibition, in the whole organism at one dose (the size of the read-out at that dose, not a potency): -5.5%
Compound 3: middle estimate off by 11.5 percentage points, on the high side; low and high end bracket the measured number.
By their numbers in this assay, from the lowest: compound 3; then compounds 2 and 1 (each within the scatter of the next).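

In this assay, within the data shown here, the phenyl on the amide nitrogen proves able to move the read-out: amino in place of hydrogen on an aromatic carbon, para to a large group, gives a number 10.1 percentage points lower from compound 2 to compound 3 (beyond the scatter), the first step in this set to lie beyond the scatter. Set against the methyl amide, 4-aminophenyl in place of methyl gives a number 15.1 percentage points lower from compound 1 to compound 3 (beyond the scatter), whereas plain phenyl in that place had stayed within the scatter of compound 1. Nothing further is available to explain this modest downward step.

Going by these compounds, it remains open whether a different group in the same place, such as a hydroxyl, a carboxylic acid or a longer amine chain, would shift the number up, down or not at all. Also open, on these data alone, is whether any change on this phenyl can raise inhibition well above the low numbers seen so far.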